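A few compounds are considered here, and "the series" means these few. Any claim that something is new, unique, unknown or untested is made for them only; others in the source may bear on it.

Measured compounds:
- compound 1, `CCOc1nc(-c2ccc(Cl)cc2Cl)c(CC)nc1NC(CC)CC`: 151 nM
- compound 2, `CCc1nc(NC(CC)CC)c(OC)nc1-c1ccc(Cl)cc1Cl`: 5.9 nM
- compound 3, `CCc1nc(NC(CC)CC)c(F)nc1-c1ccc(Cl)cc1Cl`: 167 nM

These values come from an assay on IMR-32 cells for displacement of a labelled ligand from corticotropin-releasing factor receptor 1 (Homo sapiens), read by scintillation counting, with a stated time of 2 h; on this read-out higher numbers stand for weaker inhibition and lower numbers for stronger inhibition. Among the three, compound 3 gives the highest number; compound 1 sits close to it, whereas compound 2 is clearly separated, as the step of a 28-fold higher number from compound 2 to compound 3 (1.45 log units; beyond the scatter) shows. The step of a 1.1-fold higher number from compound 1 to compound 3 (0.04 log units; within the scatter) lies within the scatter.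

Compound 4, `CCc1nc(NC(CC)CC)c(I)nc1-c1ccc(Cl)cc1Cl`, is not yet measured. It differs from compound 3 in one place: iodo in place of fluoro on an aromatic carbon. For the measured compounds named here, no measured step swaps one halogen for another, so the direct bearing is thin. What exists shows that this position is sensitive: the step of a 28-fold higher number from compound 2 to compound 3 (1.45 log units; beyond the scatter) is large, while the step of a 1.1-fold higher number from compound 1 to compound 3 (0.04 log units; within the scatter) is not. A moderate shift in either direction is therefore possible; the estimate for compound 4 is 40 nM, with a range from 8 nM to 250 nM, a step of a 4.2-fold lower number from compound 3 to compound 4 (0.62 log units; beyond the scatter).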

Compound 4, inhibition constant: 12 nM
Beside the measured number, compound 4's estimate is 3.3-fold (0.52 log units) above it, and the stated range covers the measured number.
By their numbers in this assay, from the lowest: compound 2; then compound 4; then compounds 1 and 3 (each within the scatter of the next).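

Halogens are not interchangeable at this aromatic carbon: in this assay iodo in place of fluoro gives a 14-fold lower number from compound 3 to compound 4 (1.14 log units; beyond the scatter) and so the fluoro result cannot stand for halogens in general. Iodo in place of ethoxy gives a 13-fold lower number from compound 1 to compound 4 (1.10 log units; beyond the scatter) while iodo in place of methoxy gives only a 2.0-fold higher number from compound 2 to compound 4 (0.31 log units; beyond the scatter) and so a single iodine atom comes close to methoxy without matching it. Nothing measured here explains these differences.

On these data alone, whether chloro or bromo would fall between fluoro and iodo stays open. So does how an amino or methyl group on this carbon would compare with methoxy.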